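A few compounds are considered here, and "the series" means these few. Any claim that something is new, unique, unknown or untested is made for them only; others in the source may bear on it.

In an in vitro ADME assay on microsomes (Homo sapiens) for metabolic stability (on this read-out higher numbers stand for a longer-lived compound and lower numbers for a shorter-lived compound), compound 3 (`CCc1nc(-c2ccc(Cl)cc2Cl)c(CC)nc1CC(CC)CC`) gives 0.217 h. That lies within the scatter of compound 1 (`CCc1nc(-c2ccc(Cl)cc2Cl)c(CC)nc1NC(COC)COC`), which gives 0.15 h, and of compound 2 (`CCc1nc(N(CC2CC2)CC2CC2)c(CC)nc1-c1ccc(Cl)cc1Cl`), which gives 0.133 h. The unmeasured compound 4 (`CCc1nc(-c2ccc(Cl)cc2Cl)c(CC)nc1NC(C)CN(C)C`) keeps the shared core and carries (1-((dimethylamino)methyl)ethyl)amino in place of 2-ethylbutyl on an aromatic carbon. Within the data shown here, three measured steps concern this same carbon. Exchanging an amino group for 2-ethylbutyl gave a 1.4-fold higher number from compound 1 to compound 3 (0.16 log units; within the scatter) and a 1.6-fold higher number from compound 2 to compound 3 (0.21 log units; within the scatter), and exchanging one amino group for another gave a 1.1-fold lower number from compound 1 to compound 2 (0.05 log units; within the scatter). Among the measured compounds shown here, none of these leaves the scatter, so no step beyond it is expected here, although no measured compound carries the entering group itself. Like compound 1, compound 4 has an amino link at this carbon, so the expectation leans slightly towards the value of compound 1, 0.15 h. For compound 4, the expected step is a 1.4-fold lower number from compound 3 to compound 4 (0.13 log units; within the scatter). The half-life of compound 4 is estimated at 0.16 h, with an expected range from 0.08 h to 0.32 h.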

Compound 4, half-life: 0.117 h
Beside the measured number, compound 4's estimate is 1.4-fold (0.14 log units) above it; the range from low to high includes it.
By their numbers in this assay, from the lowest: compounds 4, 2, 1 and 3 (each within the scatter of the next).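

At this aromatic carbon of the shared core, (1-((dimethylamino)methyl)ethyl)amino, the first group shown here with a dimethylamino end, stays within the scatter of all three earlier groups in this assay (a 1.9-fold lower number from compound 3 to compound 4 (0.27 log units; within the scatter); a 1.1-fold lower number from compound 2 to compound 4 (0.06 log units; within the scatter); a 1.3-fold lower number from compound 1 to compound 4 (0.11 log units; within the scatter)). Even against the all-carbon 2-ethylbutyl, this group with two nitrogens gives no step that this assay can separate from repeat scatter, so all four groups at this carbon read alike so far. No measurement shown here bears on why these groups read alike.

From the compounds shown here alone, all four compounds keep the 2,4-dichlorophenyl group and both ethyl groups, so it stays open whether a change in those places would move the half-life beyond the scatter. Going by these compounds, it also stays open whether a carboxylic acid or a morpholine at this carbon would do so.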